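Swapping the benzyl substituent on a dithiocarbamate triazole

The source may hold more compounds than are shown below. What is called first, only, known or untested is meant among the compounds shown, and "the series" means these compounds.

Three compounds share a core in which a piperazine dithiocarbamate is linked through a triazole to a benzyl group. In a functional assay on MCF7 cells (Homo sapiens) for inhibition, read by MTT assay, with a stated time of 72 h (a lower number here means a stronger inhibitor, a higher number a weaker inhibitor), compound 1 `O=C(OCc1ccccc1)N1CCN(C(=S)SCc2cn(Cc3ccccc3F)nn2)CC1` gives 7950 nM, compound 2 `Fc1ccccc1Cn1cc(CSC(=S)N2CCNCC2)nn1` gives 33200 nM and compound 3 `CC(C)(C)OC(=O)N1CCN(C(=S)SCc2cn(Cc3ccccc3Cl)nn2)CC1` gives 6090 nM. Compound 2 therefore has the highest number of the three, which is the weakest inhibition. Within the data shown here, the one single-point step measured, a 4.2-fold higher number from compound 1 to compound 2 (0.62 log units; beyond the scatter), concerns the piperazine nitrogen and not the benzyl group, so it says nothing directly about what follows.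

Compound 4 `Cc1ccc(Cn2cc(CSC(=S)N3CCNCC3)nn2)cc1` keeps the free piperazine of compound 2 and changes only the benzyl group: 4-methylphenyl in place of 2-fluorophenyl on a saturated chain carbon bound to an aromatic nitrogen. Among the measured compounds shown here, no measured pair differs in this place alone; compound 1 and compound 3 differ in two places at once, and their values simply lie close to each other. For the measured compounds named here, with no step to lean on, the expectation is for a change of a 1.1-fold lower number from compound 2 to compound 4 (0.04 log units; within the scatter), that is nothing beyond the scatter, with compound 4 estimated at 30000 nM in this assay, within a range of 12000 nM to 80000 nM.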

Compound 4, half-maximal inhibitory concentration: 53200 nM
Estimate against measurement, compound 4: 1.8-fold (0.25 log units) below, within the range that was stated.
By their numbers in this assay, from the lowest: compounds 3 and 1 (each within the scatter of the next); then compounds 2 and 4 (each within the scatter of the next).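

Among these compounds, replacing 2-fluorophenyl with 4-methylphenyl on a saturated chain carbon bound to an aromatic nitrogen gives a 1.6-fold higher number from compound 2 to compound 4 (0.20 log units; within the scatter) in this assay and is the first change seen alone at this position. With the free piperazine kept, compound 2 and compound 4 cannot be told apart, so this particular exchange of one substituted phenyl group for another has no effect that can be read from these data. Nothing measured here bears on why the two groups read alike.

On these data alone, whether an unsubstituted phenyl, a pyridine ring or a longer chain ending in an amine would move the number at this position remains open. It is also unknown whether 2-fluorophenyl and 4-methylphenyl would still read alike with benzyloxycarbonyl on the piperazine nitrogen.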